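The source may report more compounds than this note shows. Statements on the series, on what has been measured and on what is new or still open speak of the compounds shown alone.

The compounds measured so far, each reported only as a limit of the assay:

Compound 1 `O=C(N/N=C/c1ccc([N+](=O)[O-])o1)c1ccc(-c2ccccc2)cc1`: > 200000 nM
Compound 2 `Cc1cccc(C(=O)N/N=C/c2ccc([N+](=O)[O-])o2)c1`: > 200000 nM
Compound 3 `O=C(N/N=C/c1ccc([N+](=O)[O-])o1)C1CCCCC1`: > 200000 nM

Of the compounds shown here, three sharing the core of compound 1 have been tested in an ADME assay on LL24 cells (Homo sapiens) for inhibition, read by MTT assay, with a stated time of 24 h; on this read-out lower numbers stand for stronger inhibition and higher numbers for weaker inhibition. Compound 1 does not give a number there, only the limit > 200000 nM. Compound 2 likewise reaches only the limit, > 200000 nM. Compound 3 ends in the same way, at the limit > 200000 nM. Within the data shown here, compound 1 therefore cannot be placed anywhere on a numbered scale, because the limit of > 200000 nM in this assay, at which 3 of the 3 values shown sit, leaves every value shown sitting on the same boundary, with no step between measured compounds to be drawn from them.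

Compound 4 `CC(C)c1ccc(C(=O)N/N=C/c2ccc([N+](=O)[O-])o2)cc1` differs from compound 1 by isopropyl in place of phenyl on an aromatic carbon. Among the measured compounds shown here, since the three measured compounds all end at the limit, this assay offers no step on which to build a direction, and the expectation for compound 4 is none beyond the scatter: the step from compound 1 to compound 4 is expected to be a step that the limit leaves unreadable from compound 1 to compound 4. Compound 4 is estimated at 300000 nM, with a range from 100000 nM to 1000000 nM, and most probably the assay will once more report only a limit.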

Compound 4, half-maximal inhibitory concentration: > 200000 nM
Compound 4 was reported as a limit (the forecaster's own chance of this, stated with the estimate: 85%); the middle value is on the limit's open side.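

Compound 4 has the limit > 200000 nM in this assay and no number. No step can be read between compound 1 and compound 4, since neither compound gives a number: the limit of > 200000 nM in this assay, at which 4 of the 4 values shown sit. As far as these compounds go, whether any compound sharing the core of compound 1 gives a number in this assay and how isopropyl and phenyl compare there stay open.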